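Trimming a Side Chain on a Cell Growth Inhibitor

The compounds below may be only part of what the source reports. "The series", "measured", "known", "first", "only" and "open" are said of these compounds alone.

Of the compounds shown here, three sharing one core have been measured in a functional assay on K562 cells (Homo sapiens) for inhibition, read by fluorescence, with a stated time of 72 h; a lower number here means a stronger inhibitor of growth, a higher number a weaker inhibitor of growth. Compound 1, `CC(C)CCn1cnc2c(Nc3ccc(Cl)cc3)nc(N[C@H]3CC[C@H](N)CC3)nc21`, gives 1800 nM. Compound 2, `CCCCCCn1cnc2c(Nc3ccc(Cl)cc3)nc(N[C@H]3CC[C@H](N)CC3)nc21`, gives 2100 nM. Compound 3, `CCCCCCn1cnc2c(Nc3cccc(Cl)c3)nc(N[C@H]3CC[C@H](N)CC3)nc21`, gives 2300 nM. Two single changes connect them. The change isopropyl in place of butyl on a saturated chain carbon, two bonds along the chain from an aromatic nitrogen produces a 1.2-fold lower number from compound 2 to compound 1 (0.07 log units; within the scatter). The change 3-chlorophenyl in place of 4-chlorophenyl on a nitrogen on an aromatic ring produces a 1.1-fold higher number from compound 2 to compound 3 (0.04 log units; within the scatter). All three numbers therefore sit within the usual scatter of one another, and none of the three can be called a stronger or weaker inhibitor than the others.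

Compound 4, `CC(C)CCn1cnc2c(Nc3cccc(Cl)c3)nc(N[C@H]3CC[C@H](N)CC3)nc21`, has not yet been measured. It differs from compound 3 by isopropyl in place of butyl on a saturated chain carbon, two bonds along the chain from an aromatic nitrogen. This is the same change that turns compound 2 into compound 1, made at the same place, and there it gave a 1.2-fold lower number from compound 2 to compound 1 (0.07 log units; within the scatter). The cores of compound 3 and compound 2 differ only by 3-chlorophenyl in place of 4-chlorophenyl on a nitrogen on an aromatic ring, a difference that itself moved the number very little. Since the change has already been seen once to leave the number essentially where it was, the step from compound 3 to compound 4 is expected to be a 1.2-fold lower number from compound 3 to compound 4 (0.06 log units; within the scatter), resting on a 1.2-fold lower number from compound 2 to compound 1 (0.07 log units; within the scatter). Compound 4 is accordingly estimated at 2000 nM in this assay, with a likely range from 1000 nM to 4000 nM.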

Compound 4, concentration for 50% growth inhibition: 1500 nM
Beside the measured number, compound 4's estimate is 1.3-fold (0.12 log units) above it; the measured number falls inside the stated range.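

In this assay, isopropyl in place of butyl gives a 1.5-fold lower number from compound 3 to compound 4 (0.19 log units; within the scatter), and this agrees with what the same change did on the other core: the same change on two cores in this assay, a 1.2-fold lower number (0.07 log units; within the scatter) from compound 2 to compound 1 and a 1.5-fold lower number (0.19 log units; within the scatter) from compound 3 to compound 4, 1.3-fold (0.12 log units) apart, within the scatter of two such steps

The second change, 3-chlorophenyl in place of 4-chlorophenyl, gives a 1.2-fold lower number from compound 1 to compound 4 (0.08 log units; within the scatter), and it too agrees across the two cores: the same change on two cores in this assay, a 1.1-fold higher number (0.04 log units; within the scatter) from compound 2 to compound 3 and a 1.2-fold lower number (0.08 log units; within the scatter) from compound 1 to compound 4, 1.3-fold (0.12 log units) apart, within the scatter of two such steps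

For the compounds shown here, each change therefore has a similar outcome on both cores, but every step here lies within the scatter, so the agreement shows only that neither change produced a clear effect on either core, and it does not show that a change with a clear effect would carry from one core to another in the same way.

The compounds shown leave open whether a different group at the end of the chain, such as an amine or a carboxylic acid, or a much longer chain, would give a step beyond the scatter. They also leave open whether a plain phenyl or a methoxyphenyl in place of the chlorophenyl would do so, and whether such a step would hold on both cores.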